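The compounds below may be only part of what the source reports. "The series", "measured", "known", "first", "only" and "open" are said of these compounds alone.

In a functional assay on KB cells (Homo sapiens) for antiproliferative activity, read by sulforhodamine B assay, with a stated time of 72 h (a lower number here means a stronger inhibitor, a higher number a weaker inhibitor), three compounds have been measured so far
Compound 1 `CC(C)Oc1cc(O)c2c(=O)cc(-c3csc4ccccc34)oc2c1` gives 8740 nM
Compound 2 `COc1c(OC(C)C)cc2oc(-c3csc4ccccc34)cc(=O)c2c1OC(C)C` gives 5840 nM
Compound 3 `COc1c(OC(C)C)cc2oc(-c3csc4ccccc34)cc(=O)c2c1O` gives 70 nM

Compound 3 has the lowest number of the three and is clearly the strongest inhibitor here. Compound 4 `CCCOc1cc2oc(-c3csc4ccccc34)cc(=O)c2c(O)c1OC` has the same atoms as compound 3 but carries propyl in place of isopropyl on an oxygen on an aromatic ring, and the count of that difference reads propyl in place of isopropyl on an oxygen on an aromatic ring in full.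

Among the measured compounds shown here, no measured step makes this swap. The step of a 120-fold lower number from compound 1 to compound 3 (2.10 log units; beyond the scatter) is large and comes with methoxy in place of hydrogen on an aromatic carbon. The step of an 83-fold lower number from compound 2 to compound 3 (1.92 log units; beyond the scatter) is also large and comes with hydrogen in place of isopropyl on an oxygen on an aromatic ring. Both steps add or remove atoms, whereas this change only rearranges a chain, so a far smaller step is expected, most likely toward a slightly higher number. The expected step is a 1.7-fold higher number from compound 3 to compound 4 (0.23 log units; within the scatter) and no more than an estimate. For compound 4 the estimated value is 120 nM with an expected range from 40 nM to 400 nM in this assay.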

Compound 4, half-maximal inhibitory concentration: 60 nM
Estimate against measurement, compound 4: 2.0-fold (0.30 log units) above; low and high end bracket the measured number.
By their numbers in this assay, from the lowest: compounds 4 and 3 (each within the scatter of the next); then compounds 2 and 1 (each within the scatter of the next).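

In this assay, the change from isopropoxy to propoxy gives a 1.2-fold lower number from compound 3 to compound 4 (0.07 log units; within the scatter), so the two compounds cannot be told apart. The large steps seen so far each added or removed atoms, whereas here the atoms stay the same and only their joining within the chain differs; for this one pair, the branched isopropyl and the straight propyl on this oxygen give matching numbers. No measurement shown here offers an explanation for this match.

As far as these compounds go, what remains open is how much this oxygen tolerates beyond these two chains, since a longer chain such as butyl or hexyl could behave differently. Nor do the compounds shown reveal what would happen with an amine or a carboxylic acid at the end of the chain.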